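The source may report more compounds than this note shows. Statements on the series, on what has been measured and on what is new or still open speak of the compounds shown alone.

Measured compounds:
- Compound 1, `CCCc1nn(C)c2c(NC3CC3)nc(/C=C/c3nc(C)c(C)nc3C)nc12`: in a functional assay on L02 cells (Homo sapiens) for inhibition, read by Griess assay, with stated times of 1 h and 24 h (on this read-out higher numbers stand for weaker inhibition and lower numbers for stronger inhibition), compound 1 gives 706000 nM.
- Compound 2, `COc1cc(/C=C/c2nc(N3CCN(C)CC3)c3sccc3n2)cc(OC)c1OC`: in this assay compound 2 gives > 1000000 nM, a limit of the assay rather than a number.
- Compound 3, `COc1cc(/C=C/c2nc(Nc3ccc(C)cc3)c3sccc3n2)cc(OC)c1OC`: in this assay compound 3 gives < 40000 nM, again a limit of the assay rather than a number.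

Compound 3 thus stands at the strong end of what this assay reports, with no exact number behind it. Among the compounds with values here, compound 1 is the only compound with a measured number. The one measured step that connects two of these compounds is an at least 25-fold lower number from compound 2 to compound 3 (1.39 log units; beyond the scatter), where the change was (4-methylphenyl)amino in place of 4-methylpiperazin-1-yl on an aromatic carbon.

Compound 4, `COc1cc(/C=C/c2nc(Nc3ccc(O)cc3)c3sccc3n2)cc(OC)c1OC`, has not been measured. It differs from compound 3 by hydroxy in place of methyl on an aromatic carbon. Within the data shown here, no measured step touches this part of the molecule: the only step available concerns a different group, so it gives no guide to the size or direction of this change. The expectation is therefore a step that the limit leaves unreadable from compound 3 to compound 4, nothing beyond the scatter. Compound 4 is estimated at 30000 nM in this assay, with a range from 5000 nM to 150000 nM.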

Compound 4, half-maximal inhibitory concentration: > 1000000 nM
Compound 4: a limit, no number; the forecaster's own chance of this, stated with the estimate: 50%; middle value at least 33-fold (1.52 log units) from the limit.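

Replacing methyl with hydroxy on this aromatic carbon, para to a large group, changes a single heavy atom, yet in this assay it gives an at least 25-fold higher number from compound 3 to compound 4 (1.39 log units; beyond the scatter), so inhibition is clearly weaker. The earlier step showed only that (4-methylphenyl)amino reads far stronger than 4-methylpiperazin-1-yl; compound 4 adds that keeping the ring and its amino link is not enough, since what sits at the outer end of that ring also counts in these two compounds. The step from compound 2 to compound 4 cannot be read, as both values are limits of the assay and not numbers: the limit of > 1000000 nM in this assay, at which 2 of the 4 values shown sit.

Going by these compounds, compound 3 carries only a limit as well, so the true size of the drop and how much stronger than its limit compound 3 may be both stay open. Nor do the compounds shown tell how a methoxy group, an amine, a chlorine atom or a longer chain such as ethyl on this same carbon would read, or whether any of them would stay as strong as methyl.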